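Swapping a Methoxy for Fluoro on the Amide Side Chain

The source may hold more compounds than are shown below. What is called first, only, known or untested is meant among the compounds shown, and "the series" means these compounds.

Compound 1 `CNC(=O)c1cc(Oc2ccc(/C=C/c3ccccn3)cc2)ccn1` gives 21600 nM in a functional assay on HepG2 cells (Homo sapiens) for antiproliferative activity, read by CCK-8 assay, with a stated time of 48 h; a lower number here means a stronger inhibitor, a higher number a weaker inhibitor.
Compound 2 `COc1ccc(NC(=O)c2cc(Oc3ccc(/C=C/c4ccccn4)cc3)ccn2)cc1` gives 30000 nM.
Compound 3 `COc1ccc(CNC(=O)c2cc(Oc3ccc(/C=C/c4ccccn4)cc3)ccn2)cc1` gives 26000 nM.

All three compounds share one core and differ only in the group carried on the amide-type nitrogen. None of the steps among them moves the number beyond the scatter: a 1.4-fold higher number from compound 1 to compound 2 (0.14 log units; within the scatter), a 1.2-fold higher number from compound 1 to compound 3 (0.08 log units; within the scatter), and a 1.2-fold lower number from compound 2 to compound 3 (0.06 log units; within the scatter). Compound 3 therefore stands with the other two as a weak inhibitor in this assay, its number no different in any meaningful way from either neighbour.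

Compound 4 `O=C(NCc1ccc(F)cc1)c1cc(Oc2ccc(/C=C/c3ccccn3)cc2)ccn1` keeps the benzyl arm of compound 3 and changes one group on it: fluoro in place of methoxy on an aromatic carbon. Going by the values given here, no measured step touches this exact change, so the only guide is that every variation tried so far on this side of the molecule left the number where it was. On that basis, compound 4 is expected to show no change at the digits printed from compound 3 to compound 4 (within the scatter), a step of no consequence beyond the scatter. The estimated value for compound 4 is 26000 nM, within a range from 11000 nM to 60000 nM.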

Compound 4, half-maximal inhibitory concentration: 45100 nM
Estimate against measurement, compound 4: 1.7-fold (0.24 log units) below; low and high end bracket the measured number.
By their numbers in this assay, from the lowest: compounds 1, 3, 2 and 4 (each within the scatter of the next, the first and the last beyond it).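

Fluoro in place of methoxy on the benzyl arm leaves compound 3 and compound 4 within the scatter of each other (a 1.7-fold higher number from compound 3 to compound 4 (0.24 log units; within the scatter)), and the same holds when the benzyl arm of compound 4 is set against the aryl arm of compound 2 (a 1.5-fold higher number from compound 2 to compound 4 (0.18 log units; within the scatter)). Only one step among these compounds passes the scatter, and only modestly (a 2.1-fold higher number from compound 1 to compound 4 (0.32 log units; beyond the scatter)), so the methyl amide and the 4-fluorobenzyl amide can just be told apart. Nothing measured here gives a reason for these numbers.

An amine or a carboxylic acid on that aromatic carbon, in place of fluoro or methoxy, remains an open case. So does a longer chain linking the amide nitrogen to the ring, and whether either would bring the number down.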